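Methoxymethyl ether variant of the tertiary alcohol series

The source may report more compounds than this note shows. Statements on the series, on what has been measured and on what is new or still open speak of the compounds shown alone.

Compound 2 `COC/C1=C/C[C@](C)(CCC=C(C)C)/C=C/[C@@H](OC(=O)C=C(C)C)[C@](C)(O)/C=C/C1=O` gives the lowest number of the three measured, 4130 nM in a functional assay on MCF7 cells (Homo sapiens) for antiproliferative activity, read by MTT assay, with a stated time of 48 h; a higher number here means a weaker inhibitor, a lower number a stronger inhibitor. Compound 1 `COC/C1=C/C[C@](C)(CCC=C(C)C)/C=C/[C@@H](OC(=O)C=C(C)C)[C@](C)(OC)/C=C/C1=O` gives 16500 nM, and compound 3 `CC(C)=CCC[C@]1(C)/C=C/[C@@H](OC(=O)C=C(C)C)[C@](C)(O)/C=C/C(=O)/C(C[Si](c2ccccc2)(c2ccccc2)C(C)(C)C)=C\C1` gives 15800 nM. Among the compounds with values here, the one single-point step recorded is a 4.0-fold lower number from compound 1 to compound 2 (0.60 log units; beyond the scatter), a hydrogen in place of methyl on an oxygen on a saturated carbon, so freeing the hydroxyl lowers the number beyond the scatter. Within the data shown here, compound 3 and compound 2 differ at the chain carbon bound to oxygen, and the two values show compound 3 well above compound 2, though no single step is drawn for that pair.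

Compound 4 `COCOC/C1=C/C[C@](C)(CCC=C(C)C)/C=C/[C@@H](OC(=O)C=C(C)C)[C@](C)(O)/C=C/C1=O` keeps the free hydroxyl of compound 2 and carries methoxy in place of hydrogen on a saturated chain carbon bound to an oxygen on a saturated carbon. Among the measured compounds shown here, no measured step covers this exact change; the closest information is the elevated value of compound 3, whose larger substituent on the same chain carbon sits far above compound 2, and the step from compound 1 to compound 2, which concerns the other oxygen. The expectation is therefore a modest rise in the number, a 1.8-fold higher number from compound 2 to compound 4 (0.26 log units; within the scatter), not a large one. Compound 4 is estimated at 7500 nM, with a range from 2500 nM to 22000 nM.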

Compound 4, half-maximal inhibitory concentration: 3120 nM
Compound 4: the middle estimate sits 2.4-fold (0.38 log units) above what was measured, and the stated range covers the measured number.
By their numbers in this assay, from the lowest: compounds 4 and 2 (each within the scatter of the next); then compounds 3 and 1 (each within the scatter of the next).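

Working notes on the methoxymethyl position: in this assay, the change gives a 1.3-fold lower number from compound 2 to compound 4 (0.12 log units; within the scatter), so methyl ether and methoxymethoxy at this chain carbon cannot be told apart, and the free hydroxyl of both compounds stays in place. Within the data shown here, this is the first evidence that this chain carbon can carry a longer oxygen-linked group without a shift beyond the scatter, which the earlier compounds could not show, since the only other variation here was the silicon-bearing group of compound 3 at 15800 nM, against which compound 4 stands at 3120 nM. The high number of compound 3 therefore does not extend to every group larger than methoxymethyl at this place, and nothing else measured on the compounds gives a reason for either result.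

Still open, on these data alone, is how a hydroxymethyl, an aminomethyl or a carboxylic acid at this chain carbon would read, and where between methoxymethoxy and the silyl group the number begins to climb. Also open, as far as these compounds go, is whether methylating the tertiary hydroxyl would raise the number on the methoxymethoxy compound as it does on the methoxymethyl compound, as seen in a 4.0-fold lower number from compound 1 to compound 2 (0.60 log units; beyond the scatter).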